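A few compounds are considered here, and "the series" means these few. Any claim that something is new, unique, unknown or untested is made for them only; others in the source may bear on it.

Antiproliferative data in a functional assay on A549 cells (Homo sapiens) for antiproliferative activity, read by MTT assay, with a stated time of 48 h; on this read-out lower numbers stand for stronger inhibition and higher numbers for weaker inhibition:

compound 1 `CN(C)CCCCn1c(N)c(-c2nc3ccccc3o2)c2nc(C#N)c(C#N)nc21`: 5470 nM
compound 2 `CCN(CC)CCCCn1c(N)c(-c2nc3ccccc3o2)c2nc(C#N)c(C#N)nc21`: 9390 nM
compound 3 `CN(C)CCCn1c(N)c(-c2nc3ccccc3n2C)c2nc(C#N)c(C#N)nc21`: 11700 nM

Compound 1 and compound 2 share one core and differ by diethylamino in place of dimethylamino on a saturated chain carbon, four bonds along the chain from an aromatic nitrogen; in this assay the step is a 1.7-fold higher number from compound 1 to compound 2 (0.23 log units; within the scatter). Compound 3 carries another core; the difference between the two cores is not broken down here. Compound 3 and compound 2 lie within the scatter of each other, while compound 3 gives a higher number than compound 1, beyond the scatter.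

Compound 4 `CCN(CC)CCCn1c(N)c(-c2nc3ccccc3n2C)c2nc(C#N)c(C#N)nc21` awaits measurement. It differs from compound 3 by diethylamino in place of dimethylamino on a saturated chain carbon, three bonds along the chain from an aromatic nitrogen, the same kind of change as before, though here the saturated chain carbon sits three bonds along the chain from the aromatic nitrogen rather than four. A step of about the earlier size is expected, resting on a 1.7-fold higher number from compound 1 to compound 2 (0.23 log units; within the scatter) in this assay. For compound 4 the expected step is a 1.5-fold higher number from compound 3 to compound 4 (0.16 log units; within the scatter). Compound 4 is estimated at 17000 nM, between 8000 nM and 40000 nM.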

Compound 4, half-maximal inhibitory concentration: 10700 nM
For compound 4 the middle estimate is 1.6-fold (0.20 log units) above the measured one; low and high end bracket the measured number.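

On the core of compound 3, diethylamino in place of dimethylamino gives a 1.1-fold lower number from compound 3 to compound 4 (0.04 log units; within the scatter) in this assay. Set beside the earlier step, the change carries across the two cores with no difference beyond the scatter: the same change on two cores in this assay, a 1.7-fold higher number (0.23 log units; within the scatter) from compound 1 to compound 2 and a 1.1-fold lower number (0.04 log units; within the scatter) from compound 3 to compound 4, 1.9-fold (0.27 log units) apart, within the scatter of two such steps. Among the compounds shown here, neither step on its own lies beyond the scatter, and with only two pairs, which also differ in where the amine sits on the chain (three bonds along it rather than four), this does not show a transferable effect of the change or separate the core from the chain.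

Still open, from the compounds shown here alone, is how a primary amine in place of these groups would read on either core. Also open, going by these compounds, is whether a longer chain would leave the step unchanged.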